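A few compounds are considered here, and "the series" means these few. Any claim that something is new, unique, unknown or untested is made for them only; others in the source may bear on it.

For the measured compounds named here, in a functional assay on COLO 205 cells (Homo sapiens) for inhibition, read by sulforhodamine B assay (a higher number here means a weaker inhibitor of growth, a lower number a stronger inhibitor of growth), compound 3 (`Oc1ccc(-c2ccc(-c3ccc(-c4nc5c(O)cccc5[nH]4)cc3)cc2)cc1`) gives 2600 nM, the lowest of the three numbers measured so far. Compound 1 (`Cc1ccc2[nH]c(-c3ccc(-c4ccc(-c5ccc(N(C)C)cc5)cc4)cc3)nc2c1`) gives 9210 nM, and compound 2 (`CN(C)c1ccc(-c2ccc(-c3ccc(-c4nc5ccccc5[nH]4)cc3)cc2)cc1`) gives 100000 nM. Compound 4 (`CN(C)c1ccc(-c2ccc(-c3ccc(-c4nc5c(O)cccc5[nH]4)cc3)cc2)cc1`) has not yet been measured. It is compound 3 with dimethylamino in place of hydroxy on an aromatic carbon, para to a large group: dimethylamino in place of hydroxy on an aromatic carbon.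

Going by the values given here, no measured step makes this exact swap. Among the compounds with values here, the one measured step is an 11-fold higher number from compound 1 to compound 2 (1.04 log units; beyond the scatter), with hydrogen in place of methyl on an aromatic carbon. It shows that a single small change on the shared core can matter a great deal here. Compound 4 carries dimethylamino, as do compound 1 at 9210 nM and compound 2 at 100000 nM, and both of those numbers are higher than that of compound 3. Compound 4 also differs from compound 2 by a hydroxy on the core, so, by analogy with the methyl of compound 1, a number below that of compound 2 seems likely. The expected change is a 3.5-fold higher number from compound 3 to compound 4 (0.54 log units; beyond the scatter), which would mean a weaker inhibitor of growth, though this rests on very few compounds. For compound 4 the estimate is 9000 nM, with an expected range from 3000 nM to 30000 nM.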

Compound 4, concentration for 50% growth inhibition: 6320 nM
The estimate for compound 4 lay 1.4-fold (0.15 log units) above the measured number, within the range that was stated.
By their numbers in this assay, from the lowest: compound 3; then compounds 4 and 1 (each within the scatter of the next); then compound 2.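

In this assay the swap to 4-(dimethylamino)phenyl gives a 2.4-fold higher number from compound 3 to compound 4 (0.39 log units; beyond the scatter) and so changes the number only modestly, while adding hydroxy to the shared core gives a 16-fold lower number from compound 2 to compound 4 (1.20 log units; beyond the scatter) and has a much larger effect among these compounds. The 4-hydroxy-1H-benzimidazol-2-yl and 5-methyl-1H-benzimidazol-2-yl groups cannot be told apart here, since a 1.5-fold lower number from compound 1 to compound 4 (0.16 log units; within the scatter) is a step that lies within the usual scatter, and the two compounds carrying them share the dimethylamino end. There is no other data here to explain any of these differences.

The compounds shown leave open whether the large step belongs to hydroxy itself or would also appear with another small group on the core, such as methoxy, fluorine or an amine. They also leave open how far the far end of the molecule tolerates change, since only hydroxy and dimethylamino appear there, and a methoxy group, a carboxylic acid or a longer chain such as diethylamino could give quite different numbers.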